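Swapping the Para Halogen for Methyl on the Phenoxy Ring

The source may hold more compounds than are shown below. What is called first, only, known or untested is meant among the compounds shown, and "the series" means these compounds.

Measured compounds:
compound 1 `Cc1nn(C)c(Oc2ccc(F)cc2)c1/C=N\OCc1c(Cl)c(-c2ccc(Cl)cc2)nn1C` — 7250 nM
compound 2 `Cc1nn(C)c(Oc2ccc(Br)cc2)c1/C=N\OCc1c(Cl)c(-c2ccc(Cl)cc2)nn1C` — 5910 nM

In a functional assay on HCT-116 cells (Homo sapiens) for antiproliferative activity, read by MTT assay, with a stated time of 72 h (on this read-out lower numbers stand for stronger inhibition and higher numbers for weaker inhibition), compound 2 gives 5910 nM, the lower of the two numbers, with compound 1 nearest; the change a 1.2-fold lower number from compound 1 to compound 2 (0.09 log units; within the scatter) stays within the scatter. Compound 3 `Cc1ccc(Oc2c(/C=N\OCc3c(Cl)c(-c4ccc(Cl)cc4)nn3C)c(C)nn2C)cc1` differs from compound 2 by methyl in place of bromo on an aromatic carbon. Among the compounds with values here, the only measured step at this position, a 1.2-fold lower number from compound 1 to compound 2 (0.09 log units; within the scatter), was small, so another small change at the same place is expected to leave the number within the scatter. Compound 3 is therefore expected to give about 6500 nM, between 3000 nM and 14000 nM. The expected step of a 1.1-fold higher number from compound 2 to compound 3 (0.04 log units; within the scatter) is estimated to be within the scatter.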

Compound 3, half-maximal inhibitory concentration: 2850 nM
Estimate against measurement, compound 3: 2.3-fold (0.36 log units) above, and the stated range ends above it.
By their numbers in this assay, from the lowest: compound 3; then compounds 2 and 1 (each within the scatter of the next).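

Where the exchange of one halogen for the other had stayed within the scatter, methyl in place of bromo gives a 2.1-fold lower number from compound 2 to compound 3 (0.32 log units; beyond the scatter) in this assay, and methyl in place of fluoro gives a 2.5-fold lower number from compound 1 to compound 3 (0.41 log units; beyond the scatter). This position therefore does respond to its substituent, though only modestly, and the 4-methylphenoxy compound stands ahead of both 4-halophenoxy compounds. Nothing available accounts for this difference. Still open, on these data alone, is whether an ethyl, a methoxy or an amine at this place would lower the number further or raise it.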